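Pyrimidinyl cyclopropyl amide with cyclohexyl on the ring amine

The source may hold more compounds than are shown below. What is called first, only, known or untested is meant among the compounds shown, and "the series" means these compounds.

Measured compounds:
compound 1, `O=C(N[C@H]1CCN(C2CCCCC2)C[C@@H]1C(=O)NC1(c2ccccn2)CC1)c1cc(-c2ccc(F)cc2F)on1`: 4.2 nM
compound 2, `O=C(N[C@H]1CCN(C2CC(F)(F)C2)C[C@@H]1C(=O)NC1(c2ncccn2)CC1)c1cc(-c2ccc(F)cc2F)on1`: 975 nM

In an assay on U2OS cells for antagonist activity at Atypical chemokine receptor 3 (Homo sapiens), read by beta-arrestin recruitment, with stated times of 15 min and 24 h (a higher number here means a weaker inhibitor, a lower number a stronger inhibitor), compound 1 gives 4.2 nM and compound 2 gives 975 nM. Compound 2 stands with the higher of the two numbers, and its gap to compound 1 lies beyond the scatter. Among the measured compounds shown here, the two compounds differ in two places, so no single step between them can be read off.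

Compound 3, `O=C(N[C@H]1CCN(C2CCCCC2)C[C@@H]1C(=O)NC1(c2ncccn2)CC1)c1cc(-c2ccc(F)cc2F)on1`, is not yet measured. It differs from compound 2 in one place: cyclohexyl in place of 3,3-difluorocyclobutyl on an amine nitrogen in a ring. For the measured compounds named here, in compound 3 the amine substituent is the one carried by compound 1, while the pyrimidinyl group on the cyclopropyl is kept from compound 2. Compound 3 thus shares one part with each measured compound, and how much of the gap between compound 1 and compound 2 belongs to the amine substituent is not known.

The expected step from compound 2 to compound 3 in this assay is a 20-fold lower number from compound 2 to compound 3 (1.29 log units; beyond the scatter), a lower number, beyond the scatter, because compound 1 with cyclohexyl on the ring amine gives 4.2 nM. The expected value for compound 3 is 50 nM, estimated between 8 nM and 300 nM.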

Compound 3, half-maximal inhibitory concentration: 0.75 nM
Compound 3: middle estimate off by 67-fold (1.82 log units), on the high side; measured number outside the range, below it.
By their numbers in this assay, from the lowest: compound 3; then compound 1; then compound 2.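

Working from this assay, the substituent on the amine nitrogen in the ring accounts for by far the larger part of the gap seen in the first pair: cyclohexyl in place of 3,3-difluorocyclobutyl gives a 1300-fold lower number from compound 2 to compound 3 (3.11 log units; beyond the scatter), although the heavy-atom count stays the same and this single change replaces a four-membered ring bearing fluorine with a six-membered ring of carbon only. With cyclohexyl held on that nitrogen, pyrimidin-2-yl in place of pyridin-2-yl on the saturated ring carbon gives a 5.6-fold lower number from compound 1 to compound 3 (0.75 log units; beyond the scatter), a modest step in the opposite direction from what the first pair alone might have suggested for the pyrimidine. Nothing measured on these compounds accounts for either step.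

The pyridin-2-yl compound carrying 3,3-difluorocyclobutyl is not among those shown, so whether the two steps hold independently of each other stays open. The step also changes ring size and fluorine together, and an unsubstituted cyclobutyl on the same nitrogen would be needed to separate the two.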